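The source may hold more compounds than are shown below. What is called first, only, known or untested is meant among the compounds shown, and "the series" means these compounds.

Compound 1 `CC1(C)OC[C@@H](C/C=C\CCC(=O)O)[C@@H](c2cncs2)O1` gives 80 nM in an assay on isolated protein for inhibition of Thromboxane-A synthase (Homo sapiens); on this read-out lower numbers stand for stronger inhibition and higher numbers for weaker inhibition. Compound 2 `Cc1ccc(OC(C)(C)[C@H]2OC[C@@H](C/C=C\CCC(=O)O)[C@@H](c3cncs3)O2)c([N+](=O)[O-])c1` gives 18 nM in this assay.

Of the two numbers, compound 2 stands lowest; compound 1 shows a higher number, and that gap lies beyond the scatter. Compound 3 `CCCCCCn1cncc1[C@H]1O[C@@H](C(C)(C)Oc2ccc(C)cc2[N+](=O)[O-])OC[C@H]1C/C=C\CCC(=O)O` differs from compound 2 in one place: 1-hexyl-1H-imidazol-5-yl in place of 1,3-thiazol-5-yl on a saturated ring carbon. Among the compounds with values here, no measured pair shows this change, so the size of the step is open. Compound 3 is expected to move somewhat below compound 2, a step of a 2.3-fold lower number from compound 2 to compound 3 (0.35 log units; beyond the scatter) in this assay that may reach beyond the scatter. The estimate for compound 3 is 8 nM, with a range from 2 nM to 40 nM.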

Compound 3, half-maximal inhibitory concentration: 490 nM
Beside the measured number, compound 3's estimate is 61-fold (1.79 log units) below it; measured number outside the range, above it.
By their numbers in this assay, from the lowest: compound 2; then compound 1; then compound 3.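

In this assay, the group on this saturated ring carbon turns out to matter greatly: 1-hexyl-1H-imidazol-5-yl in place of 1,3-thiazol-5-yl gives a 27-fold higher number from compound 2 to compound 3 (1.43 log units; beyond the scatter) and so weakens inhibition, a large step. Within the data shown here, neither earlier compound varied this group, so this is the first view of how the position responds, and the larger group is clearly not tolerated as well here. Nothing available explains the step.

The compounds shown leave open whether the imidazole ring or the hexyl chain accounts for it. A 1-methyl-1H-imidazol-5-yl group would help separate the two.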